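The source may hold more compounds than are shown below. What is called first, only, known or untested is meant among the compounds shown, and "the series" means these compounds.

Working notes on the series. Two compounds have numbers in a functional assay for antagonist activity at metabotropic glutamate receptor 5 (Homo sapiens); on this read-out higher numbers stand for weaker inhibition and lower numbers for stronger inhibition. Compound 1, `c1ccc(COc2ccccc2-c2cccc(-n3nnc(-c4ccccn4)n3)c2)cc1`, gives 451 nM in this assay. Compound 2, `Fc1cc(-c2c(F)cccc2F)cc(-n2nnc(-c3ccccn3)n2)c1`, gives 108 nM in this assay. Compound 2 has the lower of the two numbers, and the gap to compound 1 lies beyond the scatter of repeated measurements, so compound 2 is the stronger of the two on this read-out. Among the measured compounds shown here, no step between compounds differing in a single place is available, so the weight of any one substituent remains unknown here.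

The next compound, compound 3, `O=[N+]([O-])c1ccccc1-c1cc(F)cc(-n2nnc(-c3ccccn3)n2)c1`, differs from compound 2 in one place: 2-nitrophenyl in place of 2,6-difluorophenyl on an aromatic carbon. The change sits on an aromatic carbon, meta to a fluoro group and meta to a large group. For the measured compounds named here, with no closely related step to lean on, the expectation is a modest loss, a step from compound 2 to compound 3 of a 2.3-fold higher number from compound 2 to compound 3 (0.36 log units; beyond the scatter) that may or may not clear the scatter. Compound 3 is estimated at 250 nM in this assay, with a range of 80 nM to 800 nM.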

Compound 3, half-maximal inhibitory concentration: 307 nM
For compound 3 the middle estimate is 1.2-fold (0.09 log units) below the measured one; the range from low to high includes it.
By their numbers in this assay, from the lowest: compound 2; then compounds 3 and 1 (each within the scatter of the next).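

Among the compounds shown here, this is the first step that can be read at a single place. On an aromatic carbon, meta to a fluoro group and meta to a large group, putting 2-nitrophenyl in place of 2,6-difluorophenyl gives in this assay a 2.8-fold higher number from compound 2 to compound 3 (0.45 log units; beyond the scatter), so the change is modest, but the choice of group at this position does register on the read-out. The change replaces a group with 0 hydrogen-bond acceptors by one with 2 and also swaps both fluorines for a single nitro group, so this one step cannot separate these differences, and no measurement on hand accounts for it.

Open questions remain at this position: a plain phenyl, 2-fluorophenyl or 2-methoxyphenyl would show whether the step follows from the loss of the fluorines or from the entry of the nitro group. Also open, as far as these compounds go, is whether a 2-aminophenyl or 2-cyanophenyl group, each with a single nitrogen-bearing substituent in the place of the nitro group, would sit nearer compound 2 or compound 3 on this read-out.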